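The source may report more compounds than this note shows. Statements on the series, on what has been measured and on what is new or still open speak of the compounds shown alone.

Measured so far:
- compound 1 `N#CN/C(=N\CCNC(=O)c1ccc(N=[N+]=[N-])cc1)NCCCOc1cccc(CN2CCCCC2)c1`: 7.9
- compound 2 `N#CN/C(=N\CCCNC(=O)CCc1ccccc1)NCCCOc1cccc(CN2CCCCC2)c1`: 6.07

For the measured compounds named here, in a functional assay on cardiac atrium for antagonist activity at histamine H2 receptor (Cavia porcellus) (on this read-out higher numbers stand for higher potency (the scale is a negative logarithm) and lower numbers for lower potency), compound 1 gives 7.9 and compound 2 gives 6.07; compound 2 thus stands lower of the two, the single step of a number 1.83 log units lower from compound 1 to compound 2 (beyond the scatter) separating them. Compound 3 `Cc1ccc(S(=O)(=O)NCC/N=C(\NC#N)NCCCOc2cccc(CN3CCCCC3)c2)cc1` is not yet measured. It differs from compound 2 by ((4-methylphenyl)sulfonyl)amino in place of ((phenethylcarbonyl)amino)methyl on a saturated chain carbon, two bonds along the chain from a double-bonded nitrogen. Going by the values given here, only one measured step bears on this change: a number 1.83 log units lower from compound 1 to compound 2 (beyond the scatter), in which a two-carbon spacer carrying an aryl-carbonyl amide gave a far higher number than the longer, phenethyl-bearing chain of compound 2. Compound 3 returns to the shorter spacer and places an aromatic ring directly on the sulfonyl, so compound 3 is expected to move upward in this assay by about a number 1.23 log units higher from compound 2 to compound 3 (beyond the scatter). The estimate for compound 3 in this assay is therefore 7.3, expected to fall between 6.5 and 8.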

Compound 3, negative logarithm of the antagonist equilibrium constant: 6.13
Estimate against measurement, compound 3: 1.17 log units above, and the stated range ends above it.
By their numbers in this assay, from the lowest: compounds 2 and 3 (each within the scatter of the next); then compound 1.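

Read in this assay, the step of a number 0.06 log units higher from compound 2 to compound 3 (within the scatter) shows that the ((4-methylphenyl)sulfonyl)amino and ((phenethylcarbonyl)amino)methyl groups cannot be told apart at this place on the saturated chain carbon. The step of a number 1.77 log units lower from compound 1 to compound 3 (beyond the scatter) shows a large change with the chain of compound 1 kept, so the exchange of (4-azidophenyl)carbonyl for (4-methylphenyl)sulfonyl on the amine nitrogen is enough on its own to give a large step. Nothing available explains either result.

The compounds shown leave open whether the higher number of compound 1 goes with the carbonyl or with the azido group, a question that (4-azidophenyl)sulfonyl and (4-methylphenyl)carbonyl groups on the same nitrogen would address. They also leave open what chain length does by itself, which a longer chain carrying (4-azidophenyl)carbonyl would test.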